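Piperazine nitrogen substituent and the shared core

The compounds below may be only part of what the source reports. "The series", "measured", "known", "first", "only" and "open" are said of these compounds alone.

Compound 2 `CC(C)OC(=O)N1CCC(COc2ccc(N3CCN(C(=O)c4ccco4)CC3)nc2)CC1` gives 1900 nM in a functional assay on CHO-K1 cells for agonist activity at Glucose-dependent insulinotropic receptor (Homo sapiens), read by a luciferase reporter, with a stated time of 5 h (a lower number here means that less compound is needed, a higher number that more compound is needed for the effect), the highest of the two numbers shown. Its nearest neighbour is compound 3 `CCS(=O)(=O)N1CCN(c2ccc(OCC3CCN(C(=O)OC(C)C)CC3)cn2)CC1`, which gives 1300 nM in this assay. That gap is within the scatter: a 1.5-fold lower number from compound 2 to compound 3 (0.16 log units; within the scatter). Compound 1 `CC(C)NC(=O)CN1CCN(c2ccc(OCC3CCN(C(=O)OC(C)C)CC3)cn2)CC1` is reported only as > 10000 nM, a limit of the assay rather than a number (the limit of > 10000 nM in this assay, at which 1 of the 3 values shown sits). Measured from that limit, the steps of an at least 5.2-fold lower number from compound 1 to compound 2 (0.72 log units; beyond the scatter) and an at least 7.6-fold lower number from compound 1 to compound 3 (0.88 log units; beyond the scatter) are both at least modest. Compound 4 `CC(C)OC(=O)N1CCC(COc2ccc(N3CCN(S(=O)(=O)c4cccs4)CC3)nc2)CC1` differs from compound 2 by (thiophen-2-yl)sulfonyl in place of (furan-2-yl)carbonyl on an amine nitrogen in a ring. The step that bears most directly on this exchange, from an acyl to a sulfonyl on the same ring nitrogen, stayed within the scatter, so no movement beyond the scatter is expected here: a 1.3-fold lower number from compound 2 to compound 4 (0.10 log units; within the scatter). Compound 4 is therefore estimated at 1500 nM, within 500 nM to 5000 nM.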

Compound 4, half-maximal effective concentration: 1800 nM
Compound 4: middle estimate off by 1.2-fold (0.08 log units), on the low side; the measured number falls inside the stated range.
By their numbers in this assay, from the lowest: compounds 3, 4 and 2 (each within the scatter of the next). At a limit, above all of these: compound 1.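

On the ring nitrogen, exchanging (furan-2-yl)carbonyl for (thiophen-2-yl)sulfonyl leaves the number in this assay unresolved (a 1.1-fold lower number from compound 2 to compound 4 (0.02 log units; within the scatter)). On the sulfonyl sulfur, thiophen-2-yl and ethyl are likewise not separated (a 1.4-fold higher number from compound 3 to compound 4 (0.14 log units; within the scatter)), so neither exchange resolves a preference at this position. The step from the (isopropylcarbamoyl)methyl group is only a bound (an at least 5.5-fold lower number from compound 1 to compound 4 (0.74 log units; beyond the scatter)), as compound 1 is reported at a limit: the limit of > 10000 nM in this assay, at which 1 of the 4 values shown sits.

Open, on these data alone, is whether a carboxylic acid or an amine on this ring nitrogen would differ from compound 4 beyond the scatter. Also open, as far as these compounds go, is whether a longer alkyl chain on the sulfonyl sulfur would do so.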